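This account rests on a few compounds, and the source may have more. Where it says the series, first, only, none or still open, it means among the compounds named here.

Measured compounds:
compound 1, `COC(=O)c1cc(-c2csc(N/N=C/c3cccs3)n2)ccc1OCc1ccccc1`: 96%
compound 2, `Fc1ccc(-c2csc(N/N=C/c3ccc(Cl)cc3Cl)n2)cc1`: 95.5%
compound 3, `Fc1ccc(-c2csc(N/N=C/c3cccs3)n2)cc1`: 66.3%

The three compounds share a core and were tested in a functional assay, read by spectrophotometry, with a stated time of 15 min, tested at 80 ug/mL; a lower number here means a weaker effect, a higher number a stronger effect of the compound at the concentration tested. Compound 2 stands near the top of the three numbers: in this assay compound 2 gives 95.5%, and compound 1 gives 96%, a difference that lies within the usual scatter, so the two cannot be told apart. Compound 3, which gives 66.3%, lies well beyond the scatter below compound 2.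

Compound 4, `Clc1ccc(/C=N/Nc2nc(-c3ccccc3)cs2)c(Cl)c1`, has not yet been measured. It differs from compound 2 in one place: hydrogen in place of fluoro on an aromatic carbon. Among the measured compounds shown here, no pair of measured compounds differs by this same change, so the size of its effect is not known from the data in hand. The large gap between compound 1 and compound 3 shows that substituents on the phenyl ring can matter, but that gap involves a different and larger change.

Compound 4 is therefore expected to give about 90% in this assay, with a range from 75% to 99%. The step this estimate implies, a number 5.5 percentage points lower from compound 2 to compound 4 (within the scatter), is expected to be small, a slight drop or none beyond the scatter.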

Compound 4, a percentage reported as inhibition, at one concentration (the size of the read-out at that concentration, not a potency): 92.6%
Compound 4: the middle estimate sits 2.6 percentage points below what was measured, within the range that was stated.
By their numbers in this assay, from the lowest: compound 3; then compounds 4, 2 and 1 (each within the scatter of the next).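

In this assay, among the compounds shown here, the change from 4-fluorophenyl to phenyl, with hydrogen in place of fluoro on an aromatic carbon para to a large group, gives a number 2.9 percentage points lower from compound 2 to compound 4 (within the scatter) and so provides the first measured reading of this change. With the rest of compound 2 left as it stands, the fluoro group is therefore not needed for a high read-out at this position, since compound 4 gives 92.6% at the single concentration tested. For the compounds shown here, this read-out shows the size of the effect at that concentration and not a potency, so the pair establishes only that the two compounds cannot be told apart here.

The compounds shown leave open whether an amine, a methoxy group or a carboxylic acid at this position would keep the read-out as high, and whether the same change would be equally small on compound 3, which gives 66.3% in this assay and carries a different group at the other end of the shared core. No measurement in hand accounts for the size of this step.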